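This account rests on a few compounds, and the source may have more. Where it says the series, first, only, none or still open, it means among the compounds named here.

Of the compounds shown here, two have been measured so far in an assay on Ltk cells with metabotropic glutamate receptor 5 (Homo sapiens) as the target, read by fluorescence and calcium flux; a higher number here means a weaker inhibitor, a lower number a stronger inhibitor. Compound 1 `CCOc1c(C)ccnc1Nc1cccc(C)n1` carries only small groups on the shared core, and in this assay compound 1 gives 2700 nM. Compound 2 `CCOc1cc(-c2ccccc2C#N)cnc1Nc1cccc(C)n1` adds a 2-cyanophenyl group to that core, and in this assay compound 2 gives 37 nM. Among the two numbers that of compound 2 is the lowest, and its gap to compound 1 lies well beyond the usual scatter, so compound 2 is the stronger inhibitor of the pair.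

Compound 3 `CCOc1cc(-c2ccsn2)cnc1Nc1cccc(C)n1` has not yet been measured. Against compound 2 it shows a single change: 1,2-thiazol-3-yl in place of 2-cyanophenyl on an aromatic carbon. Going by the values given here, nothing measured so far tells how much of the potency of compound 2 rests on the 2-cyanophenyl group itself rather than on having any aromatic group at that place. A modest loss is therefore expected rather than a large one, which would be a step of a 2.7-fold higher number from compound 2 to compound 3 (0.43 log units; beyond the scatter) in the direction of a weaker inhibitor. On that basis compound 3 is estimated at 100 nM, within a range from 25 nM to 400 nM.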

Compound 3, half-maximal inhibitory concentration: 243 nM
For compound 3 the middle estimate is 2.4-fold (0.39 log units) below the measured one, within the range that was stated.
By their numbers in this assay, from the lowest: compound 2; then compound 3; then compound 1.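

Swapping 2-cyanophenyl for 1,2-thiazol-3-yl on this aromatic carbon in this assay gives a 6.6-fold higher number from compound 2 to compound 3 (0.82 log units; beyond the scatter), a modest loss but one that lies beyond the scatter. The position therefore responds to which aromatic group it carries, yet a six-membered carbon ring bearing a nitrile can give way to a five-membered ring with two hetero atoms at only this modest cost. Which part of the change accounts for the loss cannot be told, as no measurement bearing on it is at hand.

The compounds shown leave open whether the difference follows the nitrile or the ring itself, since the two groups differ in both, and a plain phenyl group at this place would begin to separate these two parts of the change. They also leave open whether this position needs an aromatic group at all, a question that a morpholine ring or a short alkyl chain on the same carbon could help answer.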